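Branched Butyl Esters and Vero Cell Tolerance

This account rests on a few compounds, and the source may have more. Where it says the series, first, only, none or still open, it means among the compounds named here.

Measured so far:
compound 1, `CCCCCCCCOC(=O)C(O)Cn1cnc2c(N)ncnc21`: 200 ug/mL
compound 2, `CCCCCOC(=O)C(O)Cn1cnc2c(N)ncnc21`: 200 ug/mL
compound 3, `CC(C)COC(=O)C(O)Cn1cnc2c(N)ncnc21`: > 400 ug/mL

All three share one core and differ only in the ester chain. In a functional assay on Vero cells (Chlorocebus sabaeus) for cytotoxicity (a higher number here means that more compound is tolerated, a lower number that less compound is tolerated), compound 1 gives 200 ug/mL and compound 2 gives 200 ug/mL. For compound 3 the value > 400 ug/mL is a limit of the assay, not a number. Compound 4, `CCC(C)OC(=O)C(O)Cn1cnc2c(N)ncnc21`, has not yet been measured. It differs from compound 3 by sec-butyl in place of isobutyl on an oxygen next to a carbonyl group. Among the measured compounds shown here, the steps that bear on this are an at least 2.0-fold higher number from compound 1 to compound 3 (0.30 log units; that floor lies within the scatter) and an at least 2.0-fold higher number from compound 2 to compound 3 (0.30 log units; that floor lies within the scatter), both from heptyl or butyl to isopropyl, while no change at the digits printed from compound 1 to compound 2 (within the scatter). The change to compound 4 keeps the chain the same size, so no shift beyond the scatter is expected, a number no higher from compound 3 to compound 4 (the limit leaves the size open). Compound 4 is therefore estimated at 400 ug/mL, within 200 ug/mL to 800 ug/mL.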

Compound 4, minimum cytotoxic concentration: > 400 ug/mL
Compound 4: no number, only a limit; the forecaster's own chance of this, stated with the estimate: 60%; the middle value sits exactly at the limit.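

In this assay, a second branched chain now reaches the limit, so that outcome is not tied to isobutyl alone: sec-butyl gives an at least 2.0-fold higher number from compound 2 to compound 4 (0.30 log units; that floor lies within the scatter), and an at least 2.0-fold higher number from compound 1 to compound 4 (0.30 log units; that floor lies within the scatter). Each of these steps is only a floor. The step between the two branched esters cannot be read: the limit of > 400 ug/mL in this assay, at which 2 of the 4 values shown sit.

Going by these compounds, how much compound either branched ester tolerates past that limit stays open. So does the outcome in this assay for a tert-butyl or a benzyl chain on this oxygen.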